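Swapping Fluoro for Cyano on the Amide of Compound 2

The source may hold more compounds than are shown below. What is called first, only, known or untested is meant among the compounds shown, and "the series" means these compounds.

Compound 1 `CCOc1cc(C(=O)Nc2ccc(Cl)c(-c3nc4ccccc4s3)c2)cc(OCC)c1OCC` was tested in a functional assay on Shh Light II cells for inhibition of Sonic hedgehog protein (Mus musculus), read by reporter gene assay, with a stated time of 48 h, in the presence of a further agent that is not named here (a lower number here means a stronger inhibitor, a higher number a weaker inhibitor), where compound 1 is reported only as "not active" (no number reported), with no number attached. Going by the values given here, compound 2 `O=C(Nc1ccc(Cl)c(-c2nc3ccccc3[nH]2)c1)c1ccc(F)cc1` gives 251 nM in this assay, and this is the only numerical value in the set; since compound 1 carries no number, compound 2 cannot be ranked against any other measured compound, and no step between measured compounds is available. Compound 3 `N#Cc1ccc(C(=O)Nc2ccc(Cl)c(-c3nc4ccccc4[nH]3)c2)cc1` has not yet been measured. It differs from compound 2 by cyano in place of fluoro on an aromatic carbon; cut one bond further out, the change reads 4-fluorophenyl to 4-cyanophenyl. Among the compounds with values here, with no comparable step to lean on, the change is expected to move the value little, and the step of a 1.3-fold lower number from compound 2 to compound 3 (0.10 log units; within the scatter) is expected to stay within the usual scatter, in no certain direction. Compound 3 is therefore expected to give 200 nM, within a range of 60 nM to 700 nM.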

Compound 3, half-maximal inhibitory concentration: 185 nM
Estimate against measurement, compound 3: 1.1-fold (0.03 log units) above; low and high end bracket the measured number.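

In this assay, going by these compounds alone, this is the first step between measured compounds, and cyano in place of fluoro, on an aromatic carbon para to a large group, gives a 1.4-fold lower number from compound 2 to compound 3 (0.13 log units; within the scatter). The position therefore accepts either group with no change that can be told apart from assay scatter, even though the entering cyano counts as a hydrogen-bond acceptor and the leaving fluoro does not. Nothing measured here speaks to why the two groups read alike.

From the compounds shown here alone, whether the same position would hold up with an amine, a carboxylic acid or a longer chain such as butoxy remains open. Compound 1 differs from compound 2 and compound 3 in more than one place, so its lack of a number cannot be tied to any single change.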